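A few compounds are considered here, and "the series" means these few. Any claim that something is new, unique, unknown or untested is made for them only; others in the source may bear on it.

In a functional assay on KOPN-8 cells (Homo sapiens) for antiproliferative activity, with a stated time of 72 h (a lower number here means that less compound is needed, a higher number that more compound is needed for the effect), the measured compounds stand as follows:

Compound 1, `COC(=O)c1cc(=O)c2c(OC)cc(OC)cc2[nH]1`: > 34400 nM, a limit of the assay and not a number.
Compound 2, `COc1ccc(-c2cc(=O)c3c(OC)cc(OC)cc3n2S(=O)(=O)c2ccc([N+](=O)[O-])cc2)cc1`: 17300 nM.
Compound 3, `COc1ccc(-c2cc(=O)c3c(OC)cc(OC)cc3n2S(=O)(=O)c2c(C(C)C)cc(C(C)C)cc2C(C)C)cc1`: > 341000 nM, again a limit and not a number.

Among the compounds with values here, compound 2 is thus the only compound of the three for which this assay returns a number at all. Compound 1 sits at the limit of > 34400 nM in this assay, at which 1 of the 3 values shown sits. Compound 3 sits at the limit of > 341000 nM in this assay, at which 1 of the 3 values shown sits. No pair among these three differs in a single place, so no measured step can be read from them, and nothing here tells which part of compound 2 carries its activity.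

Compound 4, `COc1ccc(-c2cc(=O)c3c(OC)cc(OC)cc3n2S(=O)(=O)c2ccc(OC)cc2)cc1`, has not yet been measured in this assay. It differs from compound 2 in one place: methoxy in place of nitro on an aromatic carbon. Within the data shown here, with no measured step of this kind to lean on, the size and direction of the change from compound 2 to compound 4 cannot be drawn from the data; a shift within the scatter is as plausible as a moderate loss. Compound 4 is therefore expected at about 25000 nM, within a range of 8000 nM to 80000 nM, which as an estimate means a step of a 1.4-fold higher number from compound 2 to compound 4 (0.16 log units; within the scatter).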

Compound 4, half-maximal effective concentration: > 82700 nM
Compound 4 ended at the assay's limit; the forecaster's own chance of this, stated with the estimate: 35%; at least 3.3-fold (0.51 log units) between middle value and limit.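

Within the data shown here, the result gives the only measured step at this place, on an aromatic carbon para to a large group: in this assay, going from 4-nitrophenyl to 4-methoxyphenyl gives an at least 4.7-fold higher number from compound 2 to compound 4 (0.67 log units; beyond the scatter). That step has no upper end, since compound 4 gives a limit of the assay and not a number: the limit of > 82700 nM in this assay, at which 1 of the 4 values shown sits. Exchanging nitro for methoxy here therefore costs activity beyond the scatter, and compound 2 remains the only compound shown with a number in this assay.

From the compounds shown here alone, the true size of the step stays open, and this single exchange cannot tell whether the nitro group itself is needed for the activity of compound 2. Going by these compounds, how an amine, a nitrile or a carboxylic acid at this same place would stand in this assay also remains unknown.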